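The source may report more compounds than this note shows. Statements on the series, on what has been measured and on what is new or still open speak of the compounds shown alone.

Of the compounds shown here, three sharing one core have been measured in a functional assay on M14 cells (Homo sapiens) for inhibition, read by sulforhodamine B assay, with a stated time of 48 h; a lower number here means a stronger inhibitor of growth, a higher number a weaker inhibitor of growth. Compound 1, `N#C/C(=C\c1c(-c2ccccc2)[nH]c2ccccc12)C(=O)c1ccccc1`, gives 4800 nM. Compound 2, `CCOC(=O)C(=Cc1c(-c2ccccc2)[nH]c2ccccc12)C(=O)OCC`, gives 4200 nM. Compound 3, `O=C(/C(=C\c1c(-c2ccccc2)[nH]c2ccccc12)S(=O)(=O)c1ccccc1)c1ccccc1`, carries a benzoyl group and a phenylsulfonyl group on the double-bonded chain carbon and gives 15600 nM, the highest of the three numbers: it stands above compound 1, its nearest neighbour, and further still above compound 2, both gaps lying beyond the usual scatter.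

The next compound follows from compound 3 by a single change. Compound 4, `CC(=O)/C(=C\c1c(-c2ccccc2)[nH]c2ccccc12)S(=O)(=O)c1ccccc1`, differs from compound 3 as follows: methyl in place of phenyl on a carbonyl carbon. In other words, benzoyl becomes acetyl while the phenylsulfonyl group and the rest of the core are untouched.

Among the measured compounds shown here, no measured pair in this set shows what such a swap does in this assay, so the expectation rests only on the spread of the three numbers. Compound 4 is expected to land near compound 3, with a step no larger than the scatter from compound 3 to compound 4 of a 1.3-fold lower number from compound 3 to compound 4 (0.11 log units; within the scatter), in either direction. The value of compound 4 in this assay is therefore estimated at 12000 nM, with a range from 4000 nM to 35000 nM.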

Compound 4, concentration for 50% growth inhibition: 521 nM
For compound 4 the middle estimate is 23-fold (1.36 log units) above the measured one; the whole stated range lies above it.
By their numbers in this assay, from the lowest: compound 4; then compounds 2 and 1 (each within the scatter of the next); then compound 3.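

In this assay, the change from benzoyl to acetyl gives a 30-fold lower number from compound 3 to compound 4 (1.48 log units; beyond the scatter), so the group on this carbonyl carbon proves to be a place where the read-out moves strongly, with the phenylsulfonyl group and the rest of the core untouched. Among the compounds shown here, this is the first step in the set between two compounds that differ in one place; the earlier compounds could not isolate any single group in this way, and here a single methyl carbon replacing a six-membered aromatic ring of carbon goes with the much lower number, while the count of hydrogen-bond donors and acceptors stays the same. Nothing at hand explains why the number falls so far with this change.

The compounds shown leave open whether the lower number follows from the presence of methyl or simply from the absence of phenyl, which an ethyl group, a longer chain or a cyclopropyl group on this carbonyl carbon could help separate. They also leave open whether acetyl would give a step of similar size if the phenylsulfonyl group were replaced by a nitrile.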